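The source may report more compounds than this note shows. Statements on the series, on what has been measured and on what is new or still open speak of the compounds shown alone.

Two compounds of the series have numbers in an assay on CHO cells for antagonist activity at transient receptor potential cation channel subfamily V member 1 (Homo sapiens), read by FLIPR (on this read-out lower numbers stand for stronger inhibition and higher numbers for weaker inhibition), so far. Compound 1 `CC(C)CCOc1cc(C(F)(F)F)ccc1CNC(=O)C(C)c1ccc(NS(C)(=O)=O)c(F)c1` gives 0.5 nM in this assay, and compound 2 `COc1ccc(CSc2cc(C(F)(F)F)ccc2CNC(=O)C(C)c2ccc(NS(C)(=O)=O)c(F)c2)cc1` gives 2.3 nM. Among the measured compounds shown here, compound 2 therefore stands highest of the two numbers, its nearest neighbour being compound 1, and the only step so far is a 4.6-fold higher number from compound 1 to compound 2 (0.66 log units; beyond the scatter).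

Compound 3 `CCCCCc1cc(C(F)(F)F)ccc1CNC(=O)C(C)c1ccc(NS(C)(=O)=O)c(F)c1` is not yet measured in this assay. It differs from compound 2 by pentyl in place of (4-methoxybenzyl)sulfanyl on an aromatic carbon. For the measured compounds named here, the one measured step bears on this only indirectly: it shows that the five-carbon isopentyloxy chain of compound 1 gave the lower number and the (4-methoxybenzyl)sulfanyl group of compound 2 the higher one. Pentyl is again a five-carbon chain without a ring, so the number for compound 3 is expected to move back toward that of compound 1, an estimated step of a 2.3-fold lower number from compound 2 to compound 3 (0.36 log units; beyond the scatter). Compound 3 is accordingly estimated at 1 nM in this assay, within a range from 0.3 nM to 4 nM.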

Compound 3, inhibition constant: 0.4 nM
Compound 3: the middle estimate sits 2.5-fold (0.40 log units) above what was measured; the measured number falls inside the stated range.
By their numbers in this assay, from the lowest: compounds 3 and 1 (each within the scatter of the next); then compound 2.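

In this assay, pentyl in place of isopentyloxy on this aromatic carbon gives a 1.3-fold lower number from compound 1 to compound 3 (0.10 log units; within the scatter), so at this position a chain attached directly through carbon and one attached through oxygen cannot be told apart. Pentyl in place of (4-methoxybenzyl)sulfanyl gives a 5.8-fold lower number from compound 2 to compound 3 (0.76 log units; beyond the scatter), which places the two groups without a ring together and leaves the ring-bearing group of compound 2 apart from both. Nothing measured here accounts for this separation.

The compounds shown leave open whether the separation follows the sulfur link, the aromatic ring or the methoxy group, which a pentylsulfanyl or a benzyloxy group at this position would begin to separate. They also leave open how far the chain tolerates a change, for example a propyl group or a terminal amine.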